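One group exchanged in a series stuck at the limit

The compounds below may be only part of what the source reports. "The series", "measured", "known", "first", "only" and "open" are said of these compounds alone.

In a functional assay on A2780 cells (Homo sapiens) for inhibition, read by sulforhodamine B assay, with a stated time of 72 h (on this read-out higher numbers stand for weaker inhibition and lower numbers for stronger inhibition), compound 1 (`O=C(NCc1ccc(S(=O)(=O)c2ccccc2)cc1)c1ccc2ncncc2c1`) gives > 10000 nM and this is a limit of the assay, not a number. Compound 2 (`O=C(NCc1ccc(S(=O)(=O)N2CCCCC2)cc1)c1ccn2ccnc2c1`) likewise gives only a limit, > 10000 nM here. Compound 3 (`O=C(NCc1ccc(S(=O)(=O)N2CCCCC2)cc1)c1ccc2nc[nH]c2c1`) also gives only a limit, > 10000 nM again, so it has no number of its own. Together these readings show the limit of > 10000 nM in this assay, at which 3 of the 3 values shown sit, and nothing yet carries a readable potency.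

Compound 4 (`O=C(NCc1ccc(S(=O)(=O)N2CCCCC2)cc1)c1cc2ccncc2o1`) changes the group on the carbonyl carbon, whose other neighbour is the amide-type nitrogen: a group of 9 heavy atoms (7 carbon, 1 nitrogen, 1 oxygen; one five-membered aromatic ring with 1 hetero atom, one six-membered aromatic ring with 1 hetero atom) in place of a group of 9 heavy atoms (7 carbon, 2 nitrogen; one five-membered aromatic ring with 2 hetero atoms, one six-membered aromatic ring of carbon only), on a carbonyl carbon and the 1H-benzimidazol-6-yl group is gone. Among the compounds with values here, the one measured step, a step that the two limits leave unreadable from compound 2 to compound 3 and also on a carbonyl carbon, has no readable size, so no measured step fixes how large the next one should be. The entering group has a six-membered aromatic ring with 1 hetero atom, but so does the group in compound 2, which gives > 10000 nM as its limit, so that ring alone promises nothing. Any readable number in this assay could only lie on the stronger side of the limit, so the expected direction is stronger inhibition, with a very uncertain size. The expected move is an at least 100-fold lower number from compound 3 to compound 4 (2.00 log units; beyond the scatter) and this is only an estimate. The estimate for compound 4 is 100 nM with an expected range from 5 nM to 10000 nM in this wide first guess.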

Compound 4, half-maximal inhibitory concentration: 29 nM
For compound 4 the middle estimate is 3.4-fold (0.54 log units) above the measured one; low and high end bracket the measured number.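

In this assay, compound 2, compound 3 and compound 4 differ only in the group on the carbonyl carbon, and this position now proves able to carry a readable potency, with an at least 340-fold lower number from compound 3 to compound 4 (2.53 log units; beyond the scatter). The same exchange gives an at least 340-fold lower number from compound 2 to compound 4 (2.53 log units; beyond the scatter), while the step between the two earlier compounds cannot be read; the six-membered aromatic ring with 1 hetero atom is not enough on its own, as compound 2 also has such a ring in this group and yet stays at a limit, whereas compound 4 is the only one of the three with an oxygen in this group. Compound 4 also stands alone in this small set as the one compound with a number rather than: the limit of > 10000 nM in this assay, at which 3 of the 4 values shown sit.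

As far as these compounds go, what stays open is which feature of the entering group matters, since its oxygen, its ring arrangement and its lack of a hydrogen-bond donor all change together. From the compounds shown here alone, a sulfur atom in place of that oxygen, or an amine added to the six-membered ring, would begin to separate these features, and it also remains unknown whether the gain carries over to the different sulfonyl group of compound 1.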